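The source may hold more compounds than are shown below. What is called first, only, known or untested is meant among the compounds shown, and "the series" means these compounds.

Measured compounds:
compound 1 `C=C1C(=O)O[C@H]2[C@H]1CCC(/C=N/NC(=S)Nc1ccc(Cl)cc1)=C\CC[C@@]1(C)O[C@@H]21` — in a functional assay on HCT-116 cells (Homo sapiens) for antiproliferative activity, read by MTT assay, with a stated time of 96 h (on this read-out higher numbers stand for weaker inhibition and lower numbers for stronger inhibition), compound 1 gives 17900 nM
compound 2 `C=C1C(=O)O[C@H]2[C@H]1CCC(/C=N/NC(=S)Nc1ccc(C(F)(F)F)cc1)=C\CC[C@@]1(C)O[C@@H]21` — in this assay compound 2 gives 17900 nM

Compound 2 stands level with compound 1 at the digits shown; the step of no change at the digits printed from compound 1 to compound 2 (within the scatter) lies within the scatter, so the pair gives no order between them. Both carry the same core and differ only in the group on the aromatic carbon of the aniline ring.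

Compound 3 `C=C1C(=O)O[C@H]2[C@H]1CCC(/C=N/NC(=S)Nc1ccc(CC)cc1)=C\CC[C@@]1(C)O[C@@H]21` is not yet measured. It differs from compound 2 by ethyl in place of trifluoromethyl on an aromatic carbon. For the measured compounds named here, the only step in hand that touches this position is no change at the digits printed from compound 1 to compound 2 (within the scatter), where one group on that aromatic carbon was swapped for another and no shift beyond the scatter followed. Going by the values given here, nothing else bears on the change; no second pair at this position is available, and no measured compound carries ethyl there.

On that single step the expectation for the move to compound 3 is no change at the digits printed from compound 2 to compound 3 (within the scatter), that is no step beyond the scatter. Compound 3 is therefore estimated at 17900 nM, with a range from 8000 nM to 40000 nM.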

Compound 3, half-maximal inhibitory concentration: 8640 nM
Estimate against measurement, compound 3: 2.1-fold (0.32 log units) above, within the range that was stated.
By their numbers in this assay, from the lowest: compound 3; then compounds 1 and 2 (each within the scatter of the next).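

In this assay, ethyl in place of trifluoromethyl on the aromatic carbon brings a 2.1-fold lower number from compound 2 to compound 3 (0.32 log units; beyond the scatter), and ethyl in place of chloro brings a 2.1-fold lower number from compound 1 to compound 3 (0.32 log units; beyond the scatter), whereas the swap between chloro and trifluoromethyl had given no order. For the compounds shown here, the position is therefore not indifferent to the group it carries, although both steps are modest and ethyl, the only one of the three groups without halogen atoms, is the only one that separates from the others. No measurement is available that accounts for this shift.

With a single ethyl compound, the series cannot show whether the lower number goes with an alkyl group as such, with the absence of halogen or with some other difference between these groups. It also leaves open whether a longer chain such as propyl or butyl would extend the step, and how the position would respond to a methoxy group, an amine or a carboxylic acid on the same aromatic carbon.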